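A few compounds are considered here, and "the series" means these few. Any claim that something is new, unique, unknown or untested is made for them only; others in the source may bear on it.

Three compounds share a common core that carries a bromoacrylamide arm and differ only in the group hanging off one end of that core. In a functional assay on FM3A cells (Mus musculus) for inhibition, read by cell counting, with a stated time of 2 days (on this read-out lower numbers stand for stronger inhibition and higher numbers for weaker inhibition), compound 3 `C=C(Br)C(=O)Nc1cccc(-c2cn3nc(-c4ccc(F)cc4)sc3n2)c1` gives 610 nM, the lowest of the three numbers, although every gap to its neighbours stays within the scatter, so the three are not really separated. Among the measured compounds shown here, compound 1 `C=C(Br)C(=O)Nc1cccc(-c2cn3nc(Cc4ccc(OC)cc4)sc3n2)c1` gives 850 nM, and compound 2 `C=C(Br)C(=O)Nc1cccc(-c2cn3nc(Cc4ccc(Cl)cc4)sc3n2)c1` gives 1100 nM; the step of a 1.4-fold lower number from compound 1 to compound 3 (0.14 log units; within the scatter) and the step of a 1.8-fold lower number from compound 2 to compound 3 (0.26 log units; within the scatter) are both small, as is a 1.3-fold higher number from compound 1 to compound 2 (0.11 log units; within the scatter), the only step that swaps one para group for another.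

Compound 4 `C=C(Br)C(=O)Nc1cccc(-c2cn3nc(-c4ccc(OC)cc4)sc3n2)c1` departs from compound 3 by methoxy in place of fluoro on an aromatic carbon. For the measured compounds named here, no measured step makes exactly this swap; the nearest, a 1.3-fold higher number from compound 1 to compound 2 (0.11 log units; within the scatter), shows that changing the para group on a related ring moved the number very little. The expectation is therefore a step of a 1.1-fold higher number from compound 3 to compound 4 (0.03 log units; within the scatter) that stays within the scatter. Compound 4 is estimated at 650 nM in this assay, with a range from 300 nM to 1400 nM.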

Compound 4, half-maximal inhibitory concentration: 890 nM
Beside the measured number, compound 4's estimate is 1.4-fold (0.14 log units) below it; the measured number falls inside the stated range.
By their numbers in this assay, from the lowest: compounds 3, 1, 4 and 2 (each within the scatter of the next).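

In this assay, the direct swap of methoxy for fluoro on the ring, para to a large group, gives a 1.5-fold higher number from compound 3 to compound 4 (0.16 log units; within the scatter) and so does not separate these two groups at this position. With methoxy kept, 4-methoxyphenyl in place of 4-methoxybenzyl gives a 1.0-fold higher number from compound 1 to compound 4 (0.02 log units; within the scatter) and 4-methoxyphenyl in place of 4-chlorobenzyl gives a 1.2-fold lower number from compound 2 to compound 4 (0.09 log units; within the scatter) and so, on these numbers, dropping the benzyl carbon does not separate the compounds either. Nothing measured here explains why these groups read alike.

From the compounds shown here alone, whether an amine or a carboxylic acid on this ring carbon, or a longer chain in place of the ring, would move the number beyond the scatter stays open. All four compounds keep the bromoacrylamide arm, so its contribution cannot be read from them.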